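The source may report more compounds than this note shows. Statements on the series, on what has been measured and on what is new or still open speak of the compounds shown alone.

Measured so far in a functional assay on the whole organism for inhibition, with Mus musculus as the target; on this read-out higher numbers stand for an effect only at larger amounts of compound and lower numbers for an effect already at smaller amounts (lower numbers mean an effect at smaller amounts):

compound 1 `CN1Cc2c(N)cccc2C(c2ccc(Cl)cc2)C1` gives 1.1 mg/kg
compound 2 `Cc1ccc(C2CN(C)Cc3c(N)cccc32)cc1` gives about 1.2 mg/kg
compound 3 `CC(C)c1ccc(C2CN(C)Cc3c(N)cccc32)cc1` gives 68 mg/kg

Compound 1 sits at the low end of these numbers. It is level with compound 2 (the step is a 1.1-fold higher number from compound 1 to compound 2 (0.04 log units; within the scatter)), and compound 3 stands well above both (the steps are a 62-fold higher number from compound 1 to compound 3 (1.79 log units; beyond the scatter) and a 57-fold higher number from compound 2 to compound 3 (1.75 log units; beyond the scatter)).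

Compound 4 `CCCCNC(=O)Nc1cccc2c1CN(C)CC2c1ccc(Cl)cc1` is not yet measured. It differs from compound 1 by butylcarbamoyl in place of hydrogen on a nitrogen on an aromatic ring and so turns amino to (butylcarbamoyl)amino. Among the measured compounds shown here, no measured step touches this nitrogen. All three were made on an aromatic carbon, so they bear on it only indirectly. They show that one swap in this series may leave the number level or move it far upward, as in the step of a 62-fold higher number from compound 1 to compound 3 (1.79 log units; beyond the scatter) and unlike the step of a 1.1-fold higher number from compound 1 to compound 2 (0.04 log units; within the scatter). A clear upward move is therefore expected, of smaller size than the largest step seen, and with wide uncertainty (the expected step is an 11-fold higher number from compound 1 to compound 4 (1.04 log units; beyond the scatter)). Compound 4 is estimated at 12 mg/kg (expected range 2 mg/kg to 70 mg/kg).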

Compound 4, dose for half-maximal effect: 15 mg/kg
The estimate for compound 4 lay 1.3-fold (0.10 log units) below the measured number, within the range that was stated.
By their numbers in this assay, from the lowest: compounds 1 and 2 (each within the scatter of the next); then compound 4; then compound 3.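

The step at this nitrogen is the first shown away from the aromatic carbon: in this assay, butylcarbamoyl in place of hydrogen gives a 14-fold higher number from compound 1 to compound 4 (1.13 log units; beyond the scatter) and lies beyond the scatter. The number therefore responds to a change at the amino nitrogen, and compound 4 still gives a dose value of 15 mg/kg with this chain in place. Nothing in the data at hand accounts for the size of this step.

With only one group shown on this nitrogen, the share of the carbonyl part and the share of the butyl chain in the step remain open. An acetyl or methylcarbamoyl group would separate the two, and a longer chain or one ending in a carboxylic acid would show how the number follows the chain.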